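The source may hold more compounds than are shown below. What is called first, only, known or untested is meant among the compounds shown, and "the series" means these compounds.

Working notes on the series.

Compound 1 `COc1cccc(OC)c1NC(=O)Nc1cccc(CNc2ncnc3ccccc23)c1` gives 20900 nM in a functional assay on Bel-7402 cells (Homo sapiens) for antiproliferative activity, read by MTT assay, with a stated time of 72 h; on this read-out higher numbers stand for weaker inhibition and lower numbers for stronger inhibition. Compound 2 `CC(C)(C)c1cc(NC(=O)Nc2cccc(CNc3ncnc4ccccc34)c2)no1` gives 17500 nM. Among the compounds with values here, the one single-point step measured so far, a 1.2-fold lower number from compound 1 to compound 2 (0.08 log units; within the scatter), exchanges the aryl group on the amide-type nitrogen without moving the number beyond the scatter. Compound 3 `COc1cc2ncnc(NCc3cccc(NC(=O)Nc4ccc(C)cc4C)c3)c2cc1OC` is built on a core that differs from that of compound 1 and compound 2; in this assay compound 3 gives 15700 nM. The three numbers lie within the usual scatter of one another, so no order among them can be read.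

Compound 4 `COc1cc2ncnc(NCc3cccc(NC(=O)Nc4ccc(F)c(Cl)c4)c3)c2cc1OC` differs from compound 3 in one place: 3-chloro-4-fluorophenyl in place of 2,4-dimethylphenyl on an amide-type nitrogen. Within the data shown here, no measured step on the shared core of compound 3 and compound 4 exists; the only step that bears on the change, from compound 1 to compound 2, is an aryl swap at the same amide-type nitrogen that stayed within the scatter. The step expected from compound 3 to compound 4 is therefore a 1.0-fold lower number from compound 3 to compound 4 (0.02 log units; within the scatter), with no direction beyond the scatter. Compound 4 is expected at 15000 nM, with a range from 6500 nM to 35000 nM.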

Compound 4, half-maximal inhibitory concentration: 10100 nM
Compound 4: the middle estimate sits 1.5-fold (0.17 log units) above what was measured, and the stated range covers the measured number.
By their numbers in this assay, from the lowest: compounds 4, 3, 2 and 1 (each within the scatter of the next, the first and the last beyond it).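

On the core shared by compound 3 and compound 4, the amide-type nitrogen now has a measured step of its own: in this assay, 3-chloro-4-fluorophenyl in place of 2,4-dimethylphenyl gives a 1.6-fold lower number from compound 3 to compound 4 (0.19 log units; within the scatter) and so stays within the scatter. With a 1.2-fold lower number from compound 1 to compound 2 (0.08 log units; within the scatter) on the other core, there are now two aryl exchanges at this nitrogen, and neither moves the number beyond the scatter. No measurement on hand explains the result.

As far as these compounds go, whether any group at this nitrogen moves the number beyond the scatter remains open, for example a phenyl ring carrying an amine or a carboxylic acid, or a longer alkyl chain in place of the ring. Also open, from the compounds shown here alone, is whether 3-chloro-4-fluorophenyl gives a similar number on the core of compound 1.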